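Chain-extended ether analogue in the cytotoxicity series

This account rests on a few compounds, and the source may have more. Where it says the series, first, only, none or still open, it means among the compounds named here.

The shared core carries an ether on the unsaturated carbon, and the group on that ether is what varies across the set. Compound 1 `CCC1(Cc2ccccc2)OS(=O)(=O)C=C1OCCCCc1ccccc1`, compound 2 `CCC1(Cc2ccccc2)OS(=O)(=O)C=C1OCc1ccc(F)cc1` and compound 3 `CCC1(Cc2ccccc2)OS(=O)(=O)C=C1OCCCc1ccccc1` have been examined in an ADME assay on HEL cells (Homo sapiens) for cytotoxicity, with a stated time of 3 days; a higher number here means that more compound is tolerated, a lower number that less compound is tolerated. Compound 1 reaches only the limit >= 20000 nM. Compound 2 reaches only the limit >= 50000 nM. Compound 3 likewise reaches only the limit >= 20000 nM, so its standing is a limit rather than a number, and the two further values are limits as well: two of the three sit at the limit of >= 20000 nM in this assay, at which 2 of the 3 values shown sit, and one at the limit of >= 50000 nM in this assay, at which 1 of the 3 values shown sits. The steps a step that the two limits leave unreadable from compound 1 to compound 2, a step that the two limits leave unreadable from compound 1 to compound 3 and a step that the two limits leave unreadable from compound 2 to compound 3 are therefore not readable in size. Compound 4 `CCC1(Cc2ccccc2)OS(=O)(=O)C=C1OCCCCCCc1ccccc1` is the next member; the change is 3-phenylpropyl in place of phenyl on a saturated chain carbon, three bonds along the chain from an oxygen on an unsaturated carbon. Among the measured compounds shown here, the steps that bear on it are those among the earlier chain variants, all unreadable, so no step beyond the scatter is expected in this assay and the expected step of a number no higher from compound 3 to compound 4 (the limit leaves the size open) is flat. Compound 4 is expected to give 20000 nM, between 10000 nM and 50000 nM, most likely again reported only as a limit.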

Compound 4, minimum cytotoxic concentration: >= 20000 nM
Compound 4 was reported as a limit; the forecaster's own chance of this, stated with the estimate: 85%; the middle value sits exactly at the limit.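

In this assay compound 4 gives >= 20000 nM, again a limit. The steps from compound 3 and from compound 1 to compound 4 therefore cannot be read. The compounds shown leave open whether the length of the ether chain changes the minimum cytotoxic concentration at all.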